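Aryl sulfonate antiproliferatives: a methoxy swap on the ester ring

The compounds below may be only part of what the source reports. "The series", "measured", "known", "first", "only" and "open" are said of these compounds alone.

Measured compounds:
compound 1 `Cc1cccc(OS(=O)(=O)c2ccc(N3CCN(C)C3=O)cc2)c1` — 4300 nM
compound 2 `COc1cc(OS(=O)(=O)c2ccc(N3CCN(C)C3=O)cc2)cc(OC)c1OC` — 62 nM

The two compounds share a common core and differ only in the ring carried on the sulfonate oxygen. In a functional assay on HT-29 cells (Homo sapiens) for antiproliferative activity, read by sulforhodamine B assay, with a stated time of 48 h (a higher number here means a weaker inhibitor, a lower number a stronger inhibitor), compound 1 gives 4300 nM, the higher of the two numbers and so the weaker inhibitor. Compound 2 gives 62 nM in this assay, a far lower number, and the gap between them is well beyond the scatter of repeated measurements.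

Compound 3 `COc1ccc(OS(=O)(=O)c2ccc(N3CCN(C)C3=O)cc2)cc1` has not yet been measured in this assay. It differs from compound 1 as follows: 4-methoxyphenyl in place of 3-methylphenyl on an oxygen. Compound 3 is thus closer to compound 2 than compound 1 is, but it is not compound 2, and no step between two measured compounds tells how much of the gap one such change accounts for.

The step is expected to be a clear decrease, beyond the scatter, with an estimated 4.3-fold lower number from compound 1 to compound 3 (0.63 log units; beyond the scatter). Compound 3 is expected to give about 1000 nM in this assay, in a range from 300 nM to 3000 nM.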

Compound 3, half-maximal inhibitory concentration: > 100000 nM
Compound 3 was reported as a limit; the forecaster's own chance of this, stated with the estimate: 5%; middle value at least 100-fold (2.00 log units) away from the limit.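

For compound 3, the read-out in this assay is a limit of the assay and not a number: the limit of > 100000 nM in this assay, at which 1 of the 3 values shown sits.

Even so, the step can be read in one direction: 4-methoxyphenyl in place of 3-methylphenyl on an oxygen gives an at least 23-fold higher number from compound 1 to compound 3 (1.36 log units; beyond the scatter), so this change moves compound 3 away from compound 2 rather than towards it, although both carry a methoxy group on the ring. Within the data shown here, the earlier pair showed only that this ring matters, and the new result shows that a methoxy group there does not by itself go with a low number, since the ring of compound 2, which carries further methoxy groups, gives 62 nM in this assay.

On these data alone, how far compound 3 actually lies from compound 1 stays unknown, and so does the share of each methoxy group in the value of compound 2. The compounds shown also leave open whether a dimethoxyphenyl ring, or an amine or a hydroxyl group in place of the methoxy group of compound 3, would bring the number back down.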